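A few compounds are considered here, and "the series" means these few. Any claim that something is new, unique, unknown or untested is made for them only; others in the source may bear on it.

Compound 1, `CC(O)n1cnc2c(N)nc(I)nc21`, in a functional assay on L1210 cells (Mus musculus) for inhibition (a lower number here means a stronger inhibitor, a higher number a weaker inhibitor), compound 1 gives 490000 nM.
Compound 2, `Nc1nc(I)nc2c1ncn2OCCO`, in this assay compound 2 gives only a limit, > 500000 nM.
Compound 3, `CC(O)n1cnc2c(S)nc(F)nc21`, in this assay compound 3 gives only a limit, > 500000 nM.

Compound 2 differs from compound 1 by 2-hydroxyethoxy in place of 1-hydroxyethyl on an aromatic nitrogen. The step of an at least 1.0-fold higher number from compound 1 to compound 2 (0.00 log units; that floor lies within the scatter) is recorded only as a floor, since compound 2 sits at the limit of > 500000 nM in this assay, at which 2 of the 3 values shown sit. Compound 3 shares no single counted difference with compound 1; the difference between the two cores is not broken down here.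

Compound 4, `OCCOn1cnc2c(S)nc(F)nc21`, is not yet measured. It differs from compound 3 by 2-hydroxyethoxy in place of 1-hydroxyethyl on an aromatic nitrogen, the same change that turned compound 1 into compound 2, made at a place described in the same words.

In this assay compound 3 already sits at a limit, and the earlier step from compound 1 to compound 2 did not move the number to a stronger inhibitor. Compound 4 is therefore expected to remain at or beyond that limit, with a step that the limit leaves unreadable from compound 3 to compound 4 expected from compound 3. Compound 4 is estimated at 700000 nM, within 250000 nM to 2000000 nM.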

Compound 4, half-maximal inhibitory concentration: 170000 nM
Beside the measured number, compound 4's estimate is 4.1-fold (0.61 log units) above it, outside the stated range (below it).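

In this assay, putting 2-hydroxyethoxy in place of 1-hydroxyethyl on an aromatic nitrogen gives an at least 2.9-fold lower number from compound 3 to compound 4 (0.46 log units; beyond the scatter), so on this core the change brings a stronger inhibitor and a readable value. The same change does not carry over unchanged from one core to the other, and the two steps differ: the same change on two cores in this assay, an at least 1.0-fold higher number (0.00 log units; that floor lies within the scatter) from compound 1 to compound 2 and an at least 2.9-fold lower number (0.46 log units; beyond the scatter) from compound 3 to compound 4, at least 3.0-fold (0.47 log units) apart, beyond the scatter of two such steps Each step has a limit at one end, so each is only a floor and not a true size, and the result concerns these two cores alone, without giving a rule for the series: the limit of > 500000 nM in this assay, at which 2 of the 4 values shown sit.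

The compounds shown leave open which part of the difference between the core of compound 1 and the core of compound 3 goes with the different outcome, as the two cores are not separated into single changes. They also leave open how a longer chain, such as 3-hydroxypropoxy, or a carboxylic acid would read on that aromatic nitrogen.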